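A few compounds are considered here, and "the series" means these few. Any claim that something is new, unique, unknown or untested is made for them only; others in the source may bear on it.

Compound 1 `C[C@@H]1CN(c2nnc(C(F)(F)F)o2)CCN1c1ncc(OCc2ccc(OS(C)(=O)=O)cc2F)cn1` gives 156%
Compound 2 `C[C@@H]1CN(c2nnc(C(F)(F)F)o2)CCN1c1ncc(OCc2ccc(C#N)cc2C#N)cn1` gives 166%
Compound 3 `C[C@@H]1CN(c2nnc(C(F)(F)F)o2)CCN1c1ncc(OCc2ccc(CS(C)(=O)=O)cc2)cn1` gives 89%

In a functional assay on HEK293S cells with Glucose-dependent insulinotropic receptor (Homo sapiens) as the target, read by HTRF and cAMP accumulation, with a stated time of 45 min (a higher number here means a larger maximal response, a lower number a smaller maximal response), compound 1 stands second highest of the three numbers. Its nearest neighbour is compound 2, with a number 10 percentage points higher from compound 1 to compound 2 (within the scatter), so the two are not separated. Its furthest is compound 3, with a number 67 percentage points lower from compound 1 to compound 3 (beyond the scatter), and likewise a number 77 percentage points lower from compound 2 to compound 3 (beyond the scatter).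

Compound 4 `C[C@@H]1CN(C(=O)OC2(C(F)(F)F)COC2)CCN1c1ncc(OCc2ccc(OS(C)(=O)=O)cc2F)cn1` differs from compound 1 at a single place: ((3-(trifluoromethyl)oxetan-3-yl)oxy)carbonyl in place of 5-(trifluoromethyl)-1,3,4-oxadiazol-2-yl on an amine nitrogen in a ring. All three measured steps change the group on a saturated chain carbon bound to an oxygen on an aromatic ring; none of them touches the amine nitrogen in a ring where compound 4 is changed. So no measured step bears directly on this change, and the large spread seen among compounds 1, 2 and 3 tells nothing about it. The expectation therefore rests on compound 1 alone, because its 156% is the only anchor, and compound 4 is expected to show a number 21 percentage points lower from compound 1 to compound 4 (beyond the scatter) with wide uncertainty. Compound 4 is estimated at 135%, in a range from 50% to 175%.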

Compound 4, intrinsic activity: the largest response reached, in percent of the reference agonist's: 141%
For compound 4 the middle estimate is 6 percentage points below the measured one; measured number inside the range.
By their numbers in this assay, from the lowest: compound 3; then compound 4; then compounds 1 and 2 (each within the scatter of the next).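

In this assay, this is the first change shown at the amine nitrogen in a ring: ((3-(trifluoromethyl)oxetan-3-yl)oxy)carbonyl in place of 5-(trifluoromethyl)-1,3,4-oxadiazol-2-yl gives a number 15 percentage points lower from compound 1 to compound 4 (beyond the scatter). The five-membered aromatic ring is therefore not needed at this position for a maximal response above that of the reference agonist, as compound 4 with its four-membered non-aromatic ring still gives 141%. Nothing shown accounts for the size of this step.

The compounds shown leave open whether the same exchange would give a similar step alongside the 2,4-dicyanophenyl group of compound 2. They also leave open how an acetyl or tert-butoxycarbonyl group, neither carrying trifluoromethyl, would read on this nitrogen.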